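Pyridin-2-yl in Place of Phenyl on the Shared Core

A few compounds are considered here, and "the series" means these few. Any claim that something is new, unique, unknown or untested is made for them only; others in the source may bear on it.

Among the measured compounds shown here, compound 2 `O=C1O/C(=C\Cn2cc(-c3ccccc3)nn2)C(OCc2ccccc2)=C1OCc1ccccc1` is the only member of this small set with a number in a functional assay on MDA-MB-231 cells (Homo sapiens) for antiproliferative activity, read by MTT assay, with a stated time of 24 h; on this read-out lower numbers stand for stronger inhibition and higher numbers for weaker inhibition; in that assay compound 2 gives 44000 nM. Compound 1 `O=C1O/C(=C\Cn2cc(C3=CCCCC3)nn2)C(OCc2ccccc2)=C1OCc1ccccc1` reaches only the limit of the assay, with > 100000 nM. For the measured compounds named here, the one measured step, an at least 2.2-fold lower number from compound 1 to compound 2 (0.35 log units; beyond the scatter), is therefore bounded on one side by the limit of > 100000 nM in this assay, at which 1 of the 2 values shown sits, and shows only that the phenyl-bearing compound gives a number while the cyclohex-1-en-1-yl analogue does not.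

Compound 3 `O=C1O/C(=C\Cn2cc(-c3ccccn3)nn2)C(OCc2ccccc2)=C1OCc1ccccc1` differs from compound 2 by pyridin-2-yl in place of phenyl on an aromatic carbon. Going by the values given here, no measured step concerns this kind of change; the single step, an at least 2.2-fold lower number from compound 1 to compound 2 (0.35 log units; beyond the scatter), sets a phenyl against a cyclohex-1-en-1-yl group and says nothing about a nitrogen in the six-membered ring. Nothing in the set supports a move beyond the scatter in either direction, so for compound 3 the expected step is a 1.1-fold lower number from compound 2 to compound 3 (0.04 log units; within the scatter). The estimate for compound 3 is 40000 nM, with a range from 15000 nM to 100000 nM, the upper end touching the limit of the assay.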

Compound 3, half-maximal inhibitory concentration: > 100000 nM
Compound 3 ended at the assay's limit; the forecaster's own chance of this, stated with the estimate: 25%; middle value at least 2.5-fold (0.39 log units) away from the limit.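

At this place on the shared core, on an aromatic carbon of a five-membered aromatic ring with 3 nitrogen, putting pyridin-2-yl in place of phenyl gives an at least 2.2-fold higher number from compound 2 to compound 3 (0.35 log units; beyond the scatter) in this assay, so a single ring nitrogen in the six-membered aromatic ring is enough to move the result beyond the scatter. Compound 3 gives > 100000 nM, which is a limit of the assay and not a number. The step from compound 1 to compound 3 cannot be read, and of the three groups at this place only phenyl gives a number, so the step from phenyl to pyridin-2-yl is bounded on one side only: the limit of > 100000 nM in this assay, at which 2 of the 3 values shown sit.

The compounds shown leave open how pyridin-3-yl or pyridin-4-yl would read at this place, and so whether the change depends on where the ring nitrogen sits. As far as these compounds go, it also remains open whether a phenyl carrying a methoxy group, an amine or a carboxylic acid would give a lower or a higher number than compound 2 in this assay.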